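Phenoxy to sulfanyl swap on the shared core

The compounds below may be only part of what the source reports. "The series", "measured", "known", "first", "only" and "open" are said of these compounds alone.

Compound 1, `Nc1cc(N)c2nc(-c3ccccc3)c(Oc3ccc(Cl)c(Cl)c3)nc2c1`, and compound 2, `COc1ccc(CNc2nc3cc(N)cc(N)c3nc2-c2ccccc2)cc1`, share one core and have both been run in a functional assay on U-251 cells (Homo sapiens) for inhibition, read by sulforhodamine B assay, with a stated time of 48 h; a lower number here means that less compound is tolerated, a higher number that more compound is tolerated. In this assay compound 1 gives 83200 nM. Compound 2 gives 51300 nM. For the measured compounds named here, the two numbers sit within the usual scatter of one another, so compound 1 cannot be set apart from compound 2 on what has been measured; no step between measured compounds is available for this series.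

Compound 3, `Nc1cc(N)c2nc(-c3ccccc3)c(Sc3ccc(Cl)c(Cl)c3)nc2c1`, is not yet measured. It differs from compound 1 in one place: (3,4-dichlorophenyl)sulfanyl in place of 3,4-dichlorophenoxy on an aromatic carbon. The rest of the molecule, including the two amino groups and the phenyl group on the core, is unchanged.

Going by the values given here, with no measured step of this kind to lean on, the expectation from compound 1 to compound 3 in this assay is a step of a 1.2-fold lower number from compound 1 to compound 3 (0.08 log units; within the scatter), which is to say nothing beyond the scatter in either direction. On that basis compound 3 is estimated at 70000 nM, with a range from 25000 nM to 200000 nM, and the measurement will show whether the swap moves the number at all.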

Compound 3, concentration lethal to 50% of the cells: < 100000 nM
Compound 3: no number, only a limit (the forecaster's own chance of this, stated with the estimate: 20%); the middle value does not contradict the limit.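

In this assay, for the compounds shown here, compound 3 gives < 100000 nM, which is a limit of the assay and not a number, so no step from compound 1 to compound 3 can be read. The compounds shown leave open whether (3,4-dichlorophenyl)sulfanyl in place of 3,4-dichlorophenoxy changes the number in either direction.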